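A Trifluoromethyl Replacement for the Methylphenyl Cap

The compounds below may be only part of what the source reports. "The series", "measured", "known", "first", "only" and "open" are said of these compounds alone.

Compound 1 `Cc1ccccc1C(OCCOc1ccc(CC2SC(=O)NC2=O)cc1)c1ccccc1` stands without a number: in a functional assay on cells with Free fatty acid receptor 1 (Homo sapiens) as the target, read by FLIPR and calcium flux, with stated times of 20 s and 100 s (a higher number here means that more compound is needed for the effect, a lower number that less compound is needed), compound 1 is recorded as "not active" (no number reported). Its two measured relatives fare little better. Compound 2 `COc1ccc(C(OCCOc2ccc(CC3SC(=O)NC3=O)cc2)c2ccccc2)cc1` gives 17800 nM in this assay, and compound 3 `O=C1NC(=O)C(Cc2ccc(OCCOC(c3ccccc3)c3ccc(Cl)cc3)cc2)S1` is recorded as "not active" (no number reported). The unmeasured compound 4 `O=C1NC(=O)C(Cc2ccc(OCCOC(c3ccccc3)c3ccc(C(F)(F)F)cc3)cc2)S1` differs from compound 1 by a single change: 4-(trifluoromethyl)phenyl in place of 2-methylphenyl on a saturated chain carbon bound to an aromatic carbon and an oxygen on a saturated carbon. Going by the values given here, no measured pair shares this exact step, so its size can only be judged from the three values shown, which sit at the weak end or fall out of range altogether. The chemist expects compound 4 to remain in that same region in this assay, with no step beyond the scatter that can be asserted in either direction. Should a number appear, compound 4 is estimated at 20000 nM, between 5000 nM and 80000 nM.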

Compound 4, half-maximal effective concentration: 11300 nM
Compound 4: the middle estimate sits 1.8-fold (0.25 log units) above what was measured; the range from low to high includes it.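

In this assay, trifluoromethyl in place of methoxy on an aromatic carbon gives a 1.6-fold lower number from compound 2 to compound 4 (0.20 log units; within the scatter), so the two groups cannot be told apart at this position. Compound 4 joins compound 2 in giving a number, but both remain in the weak region. Steps from compound 1 or compound 3 cannot be read, as neither has a number. Nothing shown explains these values. Open, as far as these compounds go, is whether an amine or a carboxylic acid on that aromatic carbon would give a much lower number.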